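This account rests on a few compounds, and the source may have more. Where it says the series, first, only, none or still open, it means among the compounds named here.

Measured in an ADME assay on HepG2 cells (Homo sapiens) for cytotoxicity, read by trypan blue exclusion, with a stated time of 48 h, in the presence of a further agent that is not named here; a higher number here means that more compound is tolerated, a lower number that less compound is tolerated:
Compound 1 `COc1ccc2nc(C)cc(OCC(=O)Nc3ccccc3)c2c1`: > 155000 nM (a limit)
Compound 2 `COc1ccccc1NC(=O)COc1cc(C)nc2ccc(C(F)(F)F)cc12`: > 128000 nM (a limit)
Compound 3 `COc1cccc(NC(=O)COc2cc(C)nc3ccc(OC)cc23)c1`: 43000 nM

Compound 2 gives > 128000 nM, and this is a limit, not a measured number. Compound 4 `COc1ccccc1NC(=O)COc1cc(C)nc2ccc(Br)cc12` differs from compound 2 in one group, with bromo in place of trifluoromethyl on an aromatic carbon. Among the compounds with values here, no measured pair makes this swap. Within the data shown here, the only measured step is an at least 3.6-fold lower number from compound 1 to compound 3 (0.55 log units; beyond the scatter), with methoxy in place of hydrogen on an aromatic carbon. That is a different change, so it bears only loosely on this one. It does show, in this single pair, that one added group can lower the number in this assay beyond the scatter. A small move towards a lower number is therefore expected, not a large one. The expected step is an at least 1.2-fold lower number from compound 2 to compound 4 (0.10 log units; that floor lies within the scatter). Compound 4 may well be reported only as a limit too. For compound 4 the estimated value is 100000 nM, expected to fall between 35000 nM and 135000 nM.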

Compound 4, half-maximal cytotoxic concentration: > 125000 nM
Compound 4: only a limit was reported; the forecaster's own chance of this, stated with the estimate: 55%; at least 1.2-fold (0.09 log units) between middle value and limit.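

Compound 2 and compound 4 are both reported only as limits, not as measured numbers, so the step between them cannot be read. The compounds shown leave open whether bromo in place of trifluoromethyl changes how much compound is tolerated, and in which direction.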